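Nitrogen substituent variation on the shared core

The source may report more compounds than this note shows. Statements on the series, on what has been measured and on what is new or still open speak of the compounds shown alone.

Measured so far:
compound 1, `Cc1ccc2c(c1)c(=O)c(C(=O)Nc1ccc(Oc3ncnc4[nH]cc(-c5ccccc5)c34)c(F)c1)c(C)n2C`, 100 nM
compound 2, `CCCn1c(C)c(C(=O)Nc2ccc(Oc3ncnc4[nH]cc(-c5ccccc5)c34)c(F)c2)c(=O)c2cc(C)ccc21`, 530 nM
compound 3, `CCCCn1c(C)c(C(=O)Nc2ccc(Oc3ncnc4[nH]cc(-c5ccccc5)c34)c(F)c2)c(=O)c2cc(C)ccc21`, 480 nM

The series varies only the group on the aromatic nitrogen of the shared core; the read-out is an assay on isolated protein for inhibition of tyrosine-protein kinase receptor UFO (Homo sapiens), read by FRET and Z'-LYTE, with a stated time of 1.5 h; a higher number here means a weaker inhibitor, a lower number a stronger inhibitor. Compound 3 has the second highest number of the three, close to compound 2 and well apart from compound 1. The next compound, compound 4, `Cc1ccc2c(c1)c(=O)c(C(=O)Nc1ccc(Oc3ncnc4[nH]cc(-c5ccccc5)c34)c(F)c1)c(C)n2-c1ccccc1`, makes the change (phenyl in place of butyl on an aromatic nitrogen).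

For the measured compounds named here, two measured steps touch this position: a 5.3-fold higher number from compound 1 to compound 2 (0.72 log units; beyond the scatter) and a 4.8-fold higher number from compound 1 to compound 3 (0.68 log units; beyond the scatter), both modest losses on lengthening the chain. The step of a 1.1-fold lower number from compound 2 to compound 3 (0.04 log units; within the scatter) shows that further lengthening changes nothing. Going by the values given here, no measured compound carries a ring on this nitrogen, so the effect of phenyl as such is untested; what the chain series shows is that the position tolerates bulk without large loss, and that the number does not fall back toward compound 1 once the chain is longer than methyl.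

For compound 4 the expectation is therefore a number near that of compound 3, with the step estimated as a 1.1-fold lower number from compound 3 to compound 4 (0.03 log units; within the scatter). The estimate for compound 4 is 450 nM, within 130 nM to 1600 nM.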

Compound 4, half-maximal inhibitory concentration: 620 nM
For compound 4 the middle estimate is 1.4-fold (0.14 log units) below the measured one; the measured number falls inside the stated range.
By their numbers in this assay, from the lowest: compound 1; then compounds 3, 2 and 4 (each within the scatter of the next).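

In this assay the first ring on this nitrogen reads like the chains: phenyl in place of butyl gives a 1.3-fold higher number from compound 3 to compound 4 (0.11 log units; within the scatter) and phenyl in place of propyl gives a 1.2-fold higher number from compound 2 to compound 4 (0.07 log units; within the scatter) and so compounds 2, 3 and 4 cannot be told apart. Phenyl in place of methyl gives a 6.2-fold higher number from compound 1 to compound 4 (0.79 log units; beyond the scatter) which shows that the gap from compound 1 to the larger groups holds for a ring as well as for a chain, and compound 1 keeps the lowest number of the four. No measurement at hand explains why the three larger groups read alike.

Still open, as far as these compounds go, is whether a bare hydrogen on this nitrogen, or a cyclopropyl or ethyl group, falls nearer compound 1 or nearer the larger groups. Also open, from the compounds shown here alone, is whether an amine or a carboxylic acid at the end of a chain, or a methoxy on the phenyl, would move the number at all.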